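Replacing a 4-methylphenyl group with ethoxy on an inactive core

The source may hold more compounds than are shown below. What is called first, only, known or untested is meant among the compounds shown, and "the series" means these compounds.

Measured so far:
compound 1, `Cn1cc(C(N)=O)c2c(N)ncnc21`: > 100000 nM
compound 2, `Cc1ccc(Cn2cc(C(N)=O)c3c(N)ncnc32)cc1`: > 100000 nM

Compound 1 was tested in a functional assay on KB cells (Homo sapiens) for cytotoxicity; on this read-out higher numbers stand for weaker inhibition and lower numbers for stronger inhibition. In this assay compound 1 reaches only a limit, > 100000 nM. Compound 2 likewise gives only a limit in this assay, > 100000 nM. The step that the two limits leave unreadable from compound 1 to compound 2 therefore cannot be read, since both ends sit at the same limit, (the limit of > 100000 nM in this assay, at which 2 of the 2 values shown sit). Compound 2 thus stands at the limit of this assay, with no numeric value of its own.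

Compound 3, `CCOCn1cc(C(N)=O)c2c(N)ncnc21`, is not yet measured in this assay. It differs from compound 2 by ethoxy in place of 4-methylphenyl on a saturated chain carbon bound to an aromatic nitrogen. Going by the values given here, the only measured step, from compound 1 to compound 2, bears on this change but is unreadable, so no size or direction can be drawn from it. The expectation is that compound 3 stays near the limit, with an expected step that the limit leaves unreadable from compound 2 to compound 3. Compound 3 is estimated at 150000 nM, within a range from 20000 nM to 1000000 nM.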

Compound 3, half-maximal inhibitory concentration: > 100000 nM
Compound 3 ended at the assay's limit (the forecaster's own chance of this, stated with the estimate: 85%); the middle value is on the limit's open side.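

Compound 3 also stops at a limit, so no step can be read among compound 1, compound 2 and compound 3: the limit of > 100000 nM in this assay, at which 3 of the 3 values shown sit.

The compounds shown leave open whether any group on the saturated chain carbon bound to an aromatic nitrogen gives a measurable value, and how 4-methylphenyl and ethoxy truly compare there.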